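This account rests on a few compounds, and the source may have more. Where it says the series, first, only, none or still open, it means among the compounds named here.

Compound 1 `O=C(Nc1cccc(-n2cc(-c3ccncc3)c(-c3cc(O)cc(Cl)c3)n2)c1)Nc1ccc(Cl)c(C(F)(F)F)c1` carries a 3-chloro-5-hydroxyphenyl group on the shared core. In a functional assay on K562 cells (Homo sapiens) for inhibition, read by sulforhodamine B assay, with a stated time of 48 h, tested at 0.1 uM (on this read-out higher numbers stand for a weaker effect at the one concentration tested and lower numbers for a stronger effect), compound 1 gives 94%. Among the compounds with values here, its only measured neighbour is compound 2 `O=C(Nc1cccc(-n2cc(-c3ccncc3)c(-c3cc(O)cc(Cl)c3)n2)c1)Nc1ccc(Cl)c(Cl)c1`, which in this assay gives 100%; the two numbers sit within the usual scatter of each other, so compound 1 is not separated from compound 2 on this read-out. Within the data shown here, the one step measured so far, a number 6 percentage points higher from compound 1 to compound 2 (within the scatter), concerns a change on an aromatic carbon elsewhere in the molecule and leaves the hydroxy untouched. Compound 3 `COc1cc(Cl)cc(-c2nn(-c3cccc(NC(=O)Nc4ccc(Cl)c(C(F)(F)F)c4)c3)cc2-c2ccncc2)c1` is drawn from compound 1 by methyl in place of hydrogen on an oxygen on an aromatic ring. Among the measured compounds shown here, no measured step tests this change, and the single step on record, lying within the scatter, offers no pointer to a shift in either direction. The step of a number 1 percentage points higher from compound 1 to compound 3 (within the scatter) is therefore expected to stay within the scatter. Compound 3 is estimated in this assay at 95%, with a range of 82% to 105%.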

Compound 3, a percentage reported as activity, at one concentration (the size of the read-out at that concentration, not a potency): 91%
Beside the measured number, compound 3's estimate is 4 percentage points above it; the range from low to high includes it.
By their numbers in this assay, from the lowest: compounds 3, 1 and 2 (each within the scatter of the next).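

Methyl in place of hydrogen on the oxygen, hydroxy to methoxy, is now tested directly: in this assay it gives a number 3 percentage points lower from compound 1 to compound 3 (within the scatter) and so does not separate the two groups on this read-out. At the one concentration tested, the 3-chloro-5-hydroxyphenyl and 3-chloro-5-methoxyphenyl forms therefore cannot be told apart, and the hydrogen on this oxygen is not shown to matter for the read-out. No available evidence bears on this result.

From the compounds shown here alone, whether a longer chain on this oxygen, such as ethoxy or benzyloxy, or an amine in place of the hydroxy, would move the number outside the scatter remains open. Also open, going by these compounds, is whether hydroxy and methoxy would separate at a higher concentration, where a single-point read-out of this kind could show a larger effect.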